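The source may report more compounds than this note shows. Statements on the series, on what has been measured and on what is new or still open speak of the compounds shown alone.

Compound 1 `CC(C)(C)N(NC(=O)c1ccccc1)C(=O)c1ccccc1I`: 105 nM
Compound 2 `COc1ccccc1C(=O)N(NC(=O)c1ccccc1)C(C)(C)C`: 525 nM

Among the measured compounds shown here, in an assay on cells for agonist activity at ecdysone receptor (Bombyx mori), read by a luciferase reporter, with a stated time of 24 h (on this read-out lower numbers stand for an effect already at smaller amounts and higher numbers for an effect only at larger amounts of compound), compound 2 stands at the higher of the two numbers known so far; its nearest neighbour is compound 1, and the only measured step, a 5.0-fold higher number from compound 1 to compound 2 (0.70 log units; beyond the scatter), separates them. Compound 3 `CC(C)(C)N(NC(=O)c1ccccc1)C(=O)c1ccc(Cl)cc1Cl` has not yet been measured. It differs from compound 2 in one place: 2,4-dichlorophenyl in place of 2-methoxyphenyl on a carbonyl carbon. For the measured compounds named here, the one step that bears on this is a 5.0-fold higher number from compound 1 to compound 2 (0.70 log units; beyond the scatter), where a methoxy group replaced an iodo group and the number rose. Compound 3 carries two chlorine atoms on that ring and no methoxy group, so the change runs the other way, and a move back toward the number of compound 1 is expected, roughly a 3.5-fold lower number from compound 2 to compound 3 (0.54 log units; beyond the scatter). Compound 3 is therefore estimated at 150 nM, within a range of 50 nM to 500 nM.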

Compound 3, half-maximal effective concentration: 117 nM
For compound 3 the middle estimate is 1.3-fold (0.11 log units) above the measured one, within the range that was stated.
By their numbers in this assay, from the lowest: compounds 1 and 3 (each within the scatter of the next); then compound 2.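

Replacing 2-iodophenyl with 2,4-dichlorophenyl on a carbonyl carbon gives a 1.1-fold higher number from compound 1 to compound 3 (0.05 log units; within the scatter), so this assay does not separate these two groups. Replacing 2-methoxyphenyl with 2,4-dichlorophenyl gives a 4.5-fold lower number from compound 2 to compound 3 (0.65 log units; beyond the scatter), which shows that the earlier step was not tied to iodo alone: among these three compounds, the two chlorine- or iodine-bearing rings sit together and the 2-methoxyphenyl ring stands apart. Nothing at hand explains why these groups give these numbers.

The compounds shown cannot divide the result between the two chlorine atoms of compound 3, as no compound carries just one of them. Also open, on these data alone, is what a 4-chlorophenyl group, or a ring bearing an amine or a carboxylic acid, would give on this carbonyl carbon.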